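A few compounds are considered here, and "the series" means these few. Any claim that something is new, unique, unknown or untested is made for them only; others in the source may bear on it.

Three compounds share one core and differ only in the group attached to the carbonyl carbon of the side chain. Compound 1 `CC(C)(C)c1ccc(C(=O)N2CCC3(CC2)C(=O)N(CC(=O)N2CCNCC2)CN3c2ccccc2)cc1` gives 22000 nM in an assay on HEK293 cells for displacement of a labelled ligand from NPC1-like intracellular cholesterol transporter 1 (Homo sapiens); on this read-out lower numbers stand for stronger inhibition and higher numbers for weaker inhibition. Compound 2 `CC(C)(C)OC(=O)NCCNC(=O)CN1CN(c2ccccc2)C2(CCN(C(=O)c3ccc(C(C)(C)C)cc3)CC2)C1=O` gives 10900 nM in this assay, a step of a 2.0-fold lower number from compound 1 to compound 2 (0.30 log units; within the scatter). Compound 3 `CC(C)(C)c1ccc(C(=O)N2CCC3(CC2)C(=O)N(CC(=O)NCNS(C)(=O)=O)CN3c2ccccc2)cc1` gives 3200 nM in this assay and has the lowest number of the three, standing a 6.9-fold lower number from compound 1 to compound 3 (0.84 log units; beyond the scatter) and a 3.4-fold lower number from compound 2 to compound 3 (0.53 log units; beyond the scatter) apart from the others, so among these it is the strongest inhibitor.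

Compound 4 `CC(C)(C)OC(=O)NCCCNC(=O)CN1CN(c2ccccc2)C2(CCN(C(=O)c3ccc(C(C)(C)C)cc3)CC2)C1=O` has not yet been measured. The change from compound 3 is 2-((tert-butoxycarbonyl)amino)ethyl in place of methanesulfonamido on a saturated chain carbon bound to an amide-type nitrogen. Going by the values given here, the only measured step that bears on it is the move a 3.4-fold lower number from compound 2 to compound 3 (0.53 log units; beyond the scatter), since compound 4 carries the same tert-butoxycarbonyl-protected amine as compound 2 on a chain one carbon longer. Reversing that step suggests a modestly higher number, expected to be a step of a 3.4-fold higher number from compound 3 to compound 4 (0.54 log units; beyond the scatter). The estimated value for compound 4 in this assay is therefore 11000 nM, with a range from 4000 nM to 30000 nM.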

Compound 4, half-maximal inhibitory concentration: 4500 nM
Compound 4: the middle estimate sits 2.4-fold (0.39 log units) above what was measured; the range from low to high includes it.
By their numbers in this assay, from the lowest: compounds 3 and 4 (each within the scatter of the next); then compounds 2 and 1 (each within the scatter of the next).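

Lengthening the chain that carries the tert-butoxycarbonyl-protected amine makes a difference beyond the scatter (a 2.4-fold lower number from compound 2 to compound 4 (0.38 log units; beyond the scatter)), so at this position the length of the chain counts, not just the protected amine at its end. Compound 4 also stays within the scatter of compound 3 (a 1.4-fold higher number from compound 3 to compound 4 (0.15 log units; within the scatter)) and clearly improves on the piperazin-1-yl group of compound 1 (a 4.9-fold lower number from compound 1 to compound 4 (0.69 log units; beyond the scatter)), which shows that methanesulfonamido is not required here and that the larger 3-((tert-butoxycarbonyl)amino)propyl group is accepted on the amide nitrogen. The data offer no explanation for this effect of chain length.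

The compounds shown leave open whether a longer chain ending in the same protected amine would lower the number further. They also leave open whether a free amine or a carboxylic acid at the chain end would do as well.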